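A few compounds are considered here, and "the series" means these few. Any claim that something is new, unique, unknown or untested is made for them only; others in the source may bear on it.

Compound 1 `CC(C)(C)OC(=O)N1CCN(c2c(C(=O)NCc3ccc(F)cc3)nc(Br)c3cccnc23)CC1`: > 10000 nM (a limit, not a number)
Compound 2 `Nc1ccc(Nc2c(C(=O)NCc3ccc(F)cc3)nc(Br)c3cccnc23)cc1`: 7000 nM
Compound 3 `N[C@H]1CC[C@H](Nc2c(C(=O)NCc3ccc(F)cc3)nc(N3CCCCC3)c3cccnc23)CC1`: "not determined" (no result reported)

These three compounds were tested for their toxicity to cancer cells. Within the data shown here, in a functional assay on LNCaP cells (Homo sapiens) for cytotoxicity, read by MTT assay, with a stated time of 72 h (on this read-out higher numbers stand for weaker inhibition and lower numbers for stronger inhibition), compound 2 gives 7000 nM, the only actual number in this small set. The result for compound 1 is a limit of the assay, and the limit of > 10000 nM in this assay, at which 1 of the 3 values shown sits, records it as such. No result is available for compound 3, whose entry reads "not determined" (no result reported), so it offers no comparison.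

The next compound to be measured is compound 4 `CNCCCNc1c(C(=O)NCc2ccc(F)cc2)nc(Br)c2cccnc12`. It keeps the core of compound 2 and changes one group, on a nitrogen on an aromatic ring: 3-(methylamino)propyl in place of 4-aminophenyl on a nitrogen on an aromatic ring. A ring-bearing group therefore gives way to an open chain.

Among the measured compounds shown here, no measured pair of compounds shows what a change of this kind does in this assay, so there is no firm basis for predicting a large move in either direction. The expected result is no shift beyond the usual scatter, and the estimated 1.8-fold lower number from compound 2 to compound 4 (0.24 log units; within the scatter) reflects that. For the measured compounds named here, the single anchor is compound 2 at 7000 nM. The expected range is kept wide. In this assay the estimate for compound 4 is 4000 nM, with an expected range of 1000 nM to 10000 nM.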

Compound 4, half-maximal inhibitory concentration: 8000 nM
Compound 4: the middle estimate sits 2.0-fold (0.30 log units) below what was measured; low and high end bracket the measured number.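

Among these compounds, replacing 4-aminophenyl with 3-(methylamino)propyl on this nitrogen gives the first readable step at this position in this assay: a 1.1-fold higher number from compound 2 to compound 4 (0.06 log units; within the scatter). In this one pair, a group carrying a six-membered aromatic ring and an open chain with no ring cannot be told apart, so that aromatic ring is not required for the weak cytotoxicity seen here. Compound 1 stands at a limit of the assay rather than at a number, and that limit leaves little room above the two readings in this pair: the limit of > 10000 nM in this assay, at which 1 of the 4 values shown sits.

On these data alone, it remains open whether any group on this nitrogen can bring the number far lower, and a longer chain, a chain ending in a carboxylic acid, or a morpholine ring would each test this against compound 2. The part played by the bromine shared by compound 2 and compound 4 also remains open, since the compounds shown offer no readable comparison in which it is replaced by another group, such as a methoxy group or a nitrile.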